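Dropping the carboxymethoxy group from compound 1

This account rests on a few compounds, and the source may have more. Where it says the series, first, only, none or still open, it means among the compounds named here.

In an ADME assay on BJ cells (Homo sapiens) for cytotoxicity, with a stated time of 72 h (a lower number here means that less compound is needed, a higher number that more compound is needed for the effect), compound 1 (`O=C(O)COc1cc(Cl)c(C(=O)Nc2cccc(-c3nc4ccccc4s3)c2)cc1[N+](=O)[O-]`) gives > 25000 nM as its reading, which is a limit of the assay and not a number. Compound 1 thus stands at the limit of > 25000 nM in this assay, at which 2 of the 3 values shown sit, and has no exact value. Compound 2 (`Cc1ccc(-c2nc3ccccc3s2)cc1NC(=O)c1cc([N+](=O)[O-])c(N2CCC(C(=O)O)CC2)cc1Cl`) gives > 25000 nM as its reading, again only a limit. Compound 3 (`O=C(Nc1nc(-c2ccc(Cl)cc2)cs1)c1cc([N+](=O)[O-])ccc1Cl`) has a different core and in this assay gives 18000 nM as a true number.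

The step to compound 4 (`O=C(Nc1cccc(-c2nc3ccccc3s2)c1)c1cc([N+](=O)[O-])ccc1Cl`) puts hydrogen in place of carboxymethoxy on an aromatic carbon, ortho to a nitro group and meta to a chloro group (hydrogen in place of carboxymethoxy on an aromatic carbon) and leaves the rest of compound 1 unchanged. Among the measured compounds shown here, no measured pair shows this change alone, so its size must be judged indirectly. Compound 3 also lacks carboxymethoxy and shows 18000 nM as its reading, a weak hint toward a modest move to a lower number. Compound 2 also lacks the group and goes against this hint, with > 25000 nM as its limit reading.

The expected change is an at least 1.6-fold lower number from compound 1 to compound 4 (0.22 log units; that floor lies within the scatter) as an estimate, and another limit reading remains quite possible. The estimate for compound 4 in this assay is an expected 15000 nM within a range from 5000 nM to 25000 nM as its likely bounds.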

Compound 4, half-maximal effective concentration in the BJ assay: > 27000 nM
Compound 4: a limit, no number; the forecaster's own chance of this, stated with the estimate: 45%; middle value at least 1.8-fold (0.25 log units) from the limit.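

In the BJ assay compound 1 gives > 25000 nM as its reading, which is a limit of the assay and not a number. In the BJ assay compound 4 gives > 27000 nM as its reading, again only a limit. Among the compounds shown here, no step between the two can therefore be read. The compounds shown leave open whether hydrogen in place of carboxymethoxy changes the reading in the BJ assay at all, although in a physicochemical assay for solubility, read by spectrophotometry, in phosphate buffer, measured as kinetic solubility, with a stated time of 18 h, at pH 7.4 (on this read-out lower numbers stand for lower solubility and higher numbers for higher solubility), the same change gives a 12-fold lower number from compound 1 to compound 4 (1.06 log units; beyond the scatter) as its result. In the physicochemical assay compound 1 gives 6700 nM and compound 4 gives 580 nM as their readings.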